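Shifting the Halogen Around the Aryl Ring

The compounds below may be only part of what the source reports. "The series", "measured", "known", "first", "only" and "open" are said of these compounds alone.

Measured so far:
compound 1 `Cc1ccc(C)c(N2CCN(C(=O)c3oc(C)nc3-c3ccc(F)cc3)CC2)c1` — 358 nM
compound 2 `Cc1ccc(C)c(N2CCN(C(=O)c3oc(C)nc3-c3cccc(F)c3)CC2)c1` — 204 nM

Of the compounds shown here, two have been measured in a functional assay on HL-60 cells (Homo sapiens) for inhibition, read by MTT assay, with a stated time of 72 h; a higher number here means a weaker inhibitor, a lower number a stronger inhibitor. Compound 1 gives 358 nM, while compound 2 gives 204 nM, the lowest of the two numbers. Within the data shown here, the one step between them, a 1.8-fold lower number from compound 1 to compound 2 (0.24 log units; within the scatter), falls within the scatter, so the two cannot be told apart with confidence.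

Compound 3 `Cc1ccc(C)c(N2CCN(C(=O)c3oc(C)nc3-c3ccccc3Cl)CC2)c1` is the next compound. It differs from compound 2 in one place: 2-chlorophenyl in place of 3-fluorophenyl on an aromatic carbon. Among the measured compounds shown here, the only step that bears on this is the halogen move from compound 1 to compound 2, and that step was within the scatter. A second move of the halogen is therefore expected to leave the number close to where compound 2 stands, with no change beyond the scatter, although the wider uncertainty is reflected in a broad range. The expected step is a 1.4-fold higher number from compound 2 to compound 3 (0.14 log units; within the scatter). Compound 3 is estimated at 280 nM, with a range from 90 nM to 900 nM.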

Compound 3, half-maximal inhibitory concentration: > 1000 nM
Compound 3 gave a limit, no number; the forecaster's own chance of this, stated with the estimate: 5%; middle value at least 3.5-fold (0.55 log units) from the limit.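

In this assay compound 3 reads > 1000 nM, which is a limit of the assay and not a number: the limit of > 1000 nM in this assay, at which 1 of the 3 values shown sits.

Even so, the limit can be read against the earlier compounds, and it shows an at least 4.9-fold higher number from compound 2 to compound 3 (0.69 log units; beyond the scatter) and an at least 2.7-fold higher number from compound 1 to compound 3 (0.44 log units; beyond the scatter). Where the two fluorophenyl compounds could not be told apart, 2-chlorophenyl on this aromatic carbon, next to the ring nitrogen, gives the first change beyond the scatter, so this place does not treat every halogen-bearing phenyl group alike.

Compound 3 changes both the halogen and where it sits on the phenyl ring, and the compounds shown cannot separate these two changes. A 2-fluorophenyl or a 3-chlorophenyl group at this place would bear directly on that question, and a plain phenyl group would show how the ring behaves with no halogen at all.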